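The compounds below may be only part of what the source reports. "The series", "measured", "known", "first", "only" and "open" are said of these compounds alone.

Measured so far:
compound 1, `Oc1cc(-c2ccccc2)nc2c(O)cccc12` — in a functional assay on P388 cells (Mus musculus) for cytotoxicity (on this read-out higher numbers stand for an effect only at larger amounts of compound and lower numbers for an effect already at smaller amounts), a limit of the assay only: > 10 ug/mL
compound 2, `COCOc1ccc(-c2cc(=O)c3ccccc3n2C)cc1` — in this assay a limit of the assay only: > 10 ug/mL

Compound 2 stands at the limit of > 10 ug/mL in this assay, at which 2 of the 2 values shown sit. Among the measured compounds shown here, neither measured compound yields a number, so no step between measured compounds can be drawn, and nothing in the numbers separates compound 1 from compound 2.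

Compound 3, `Cn1c(-c2ccc(O)cc2)cc(=O)c2ccccc21`, is the unmeasured neighbour of compound 2. The change is hydrogen in place of methoxymethyl on an oxygen on an aromatic ring.

With no measured step to lean on and both shown values sitting at a limit, the step of a number no higher from compound 2 to compound 3 (the limit leaves the size open) in this assay is expected to be of no size beyond the scatter, in neither direction. Compound 3 is accordingly estimated at 10 ug/mL, with a range from 3 ug/mL to 30 ug/mL, and a further limit rather than a number is the more likely outcome.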

Compound 3, half-maximal effective concentration: > 10 ug/mL
Compound 3: no number, only a limit; the forecaster's own chance of this, stated with the estimate: 60%; the middle value sits exactly at the limit.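

Compound 2 and compound 3 each give only a limit of the assay in this assay, so no step can be read for hydrogen in place of methoxymethyl. The compounds shown leave open whether any change on the shared core gives a readable number in this assay: the limit of > 10 ug/mL in this assay, at which 3 of the 3 values shown sit.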